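The source may hold more compounds than are shown below. What is called first, only, known or untested is meant among the compounds shown, and "the series" means these compounds.

Compound 1 `COc1ccc(-n2cc(CNCCN3CCN(C)CC3)c(-c3ccccc3C)n2)cc1`: in an ADME assay on Huh-7 cells (Homo sapiens) for cytotoxicity (a higher number here means that more compound is tolerated, a lower number that less compound is tolerated), compound 1 gives > 20000 nM, which is a limit of the assay rather than a number.
Compound 2 `Cc1cccc(-c2nn(-c3ccc(F)cc3F)cc2CNCCN2CCN(C)CC2)c1`: in this assay compound 2 gives > 20000 nM, again a limit of the assay.
Compound 3 `CCCN1CCC(CNCc2cn(-c3ccc([N+](=O)[O-])cc3)nc2-c2ccc(C(F)(F)F)cc2)CC1`: in this assay compound 3 gives 2300 nM.

Compound 1 stands at the limit of > 20000 nM in this assay, at which 2 of the 3 values shown sit, so only a floor is known for it, not an exact value. Compound 4 `Cc1ccccc1-c1nn(-c2cccc(C(F)(F)F)c2)cc1CNCCN1CCN(C)CC1` differs from compound 1 in one place: 3-(trifluoromethyl)phenyl in place of 4-methoxyphenyl on an aromatic nitrogen. Within the data shown here, no pair of measured compounds that differ in a single place is available, so the size of this step cannot be read from any neighbours. Among the measured compounds shown here, the three shared-core compounds measured so far spread from a limit to the value of compound 3, without any one of them showing what a change on that aromatic nitrogen does. In this assay the step from compound 1 to compound 4 is expected to be small, most likely within the scatter, with a slight lean toward less compound tolerated, an at least 1.6-fold lower number from compound 1 to compound 4 (0.22 log units; that floor lies within the scatter). Compound 4 is therefore expected to give about 12000 nM, estimated between 4000 nM and 30000 nM, with a real chance that only a limit is reported.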

Compound 4, half-maximal cytotoxic concentration: 18000 nM
Compound 4: the middle estimate sits 1.5-fold (0.18 log units) below what was measured; the range from low to high includes it.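

In this assay, putting 3-(trifluoromethyl)phenyl in place of 4-methoxyphenyl on the aromatic nitrogen gives an at least 1.1-fold lower number from compound 1 to compound 4 (0.04 log units; that floor lies within the scatter). Unlike compound 1 and compound 2, compound 4 gives an actual number, 18000 nM, so this part of the series now has one exact value to compare against. The true size of the step remains unknown because compound 1 has only a limit and not a number: the limit of > 20000 nM in this assay, at which 2 of the 4 values shown sit.

On these data alone, whether the aromatic nitrogen tolerates other groups equally well stays open, for instance a phenyl ring carrying a carboxylic acid or a primary amine. Compound 3 differs from the others in more than one place, so its value cannot be tied to any single change.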